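Nitrooxy chain step from compound 3 to compound 4

A few compounds are considered here, and "the series" means these few. Any claim that something is new, unique, unknown or untested is made for them only; others in the source may bear on it.

In an ADME assay for permeability, using PAMPA, at pH 7.4 (on this read-out lower numbers stand for lower permeability and higher numbers for higher permeability), compound 1 (`CC(C)(C)/[N+]([O-])=C/c1cccc(C(F)(F)F)c1`) gives 27 10^-6 cm/s and compound 2 (`Cc1ccc2nc(Cl)c(/C=[N+](\[O-])C(C)(C)C)cc2c1`) gives 15 10^-6 cm/s. Compound 3 (`O=[N+]([O-])OCCCOc1ccc(/C=[N+](\[O-])Cc2ccccc2)cc1`) gives 22 10^-6 cm/s, which stands within the scatter of both other numbers, so these data do not set it apart from either compound.

Compound 4 (`O=[N+]([O-])OCCOc1ccc(/C=[N+](\[O-])Cc2ccccc2)cc1`) has not yet been measured in this assay. Its structure differs from that of compound 3 by nitrooxy in place of (nitrooxy)methyl on a saturated chain carbon, two bonds along the chain from an oxygen on an aromatic ring. Read one bond further out, 3-(nitrooxy)propoxy becomes 2-(nitrooxy)ethoxy. Among the compounds with values here, no measured pair shows this change, so the expectation rests on compound 3 at 22 10^-6 cm/s and leans only slightly downward. The expected step of a 1.2-fold lower number from compound 3 to compound 4 (0.06 log units; within the scatter) stays within the scatter. For compound 4 the estimated value is 19 10^-6 cm/s, with an expected range of 10 10^-6 cm/s to 36 10^-6 cm/s.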

Compound 4, apparent permeability: 16.8 10^-6 cm/s
For compound 4 the middle estimate is 1.1-fold (0.05 log units) above the measured one; low and high end bracket the measured number.
By their numbers in this assay, from the lowest: compounds 2, 4, 3 and 1 (each within the scatter of the next).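

Replacing 3-(nitrooxy)propoxy with 2-(nitrooxy)ethoxy gives, in this assay, a 1.3-fold lower number from compound 3 to compound 4 (0.12 log units; within the scatter). Within the data shown here, this is the first direct read of this position, since the earlier compounds offered no pair differing in one place. On this evidence, the assay does not separate the two chain lengths on the shared core, and no measurement on hand explains the size of the step.

Going by these compounds, a single step gives no trend with chain length, so it remains open whether a longer chain would stay within the scatter of compound 3. On these data alone, it is also open whether an amine or a hydroxyl group in place of the nitrooxy group at the chain end would give a step beyond the scatter.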